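A few compounds are considered here, and "the series" means these few. Any claim that something is new, unique, unknown or untested is made for them only; others in the source may bear on it.

In a functional assay on SMMC-7721 cells (Homo sapiens) for cytotoxicity, read by MTT assay, with a stated time of 72 h (on this read-out lower numbers stand for stronger inhibition and higher numbers for weaker inhibition), compound 2 `COc1ccc(C=C2C(=O)N(c3ccc(Cl)cc3)N(c3ccc(Cl)cc3)C2=O)cc1OC` reads > 128000 nM, which is a limit and not a number, and it stands at the limit of > 128000 nM in this assay, at which 1 of the 2 values shown sits. Within the data shown here, compound 1 `O=C1C(=Cc2ccc(Br)cc2)C(=O)N(c2ccc(Cl)cc2)N1c1ccc(Cl)cc1` gives 16600 nM, and the only measured step is an at least 7.7-fold higher number from compound 1 to compound 2 (0.88 log units; beyond the scatter). Compound 3 `O=C1C(=Cc2ccc(Cl)cc2Cl)C(=O)N(c2ccc(Cl)cc2)N1c1ccc(Cl)cc1` carries 2,4-dichlorophenyl in place of 3,4-dimethoxyphenyl on a double-bonded chain carbon bound to a double-bonded ring carbon. This measured step bears most directly on the change, since the group in compound 3 holds halogen rather than methoxy, as in compound 1 at 16600 nM. The expected change, toward stronger inhibition, is an at least 5.8-fold lower number from compound 2 to compound 3 (0.76 log units; beyond the scatter). For compound 3 the estimated value is 22000 nM, with an expected range from 7000 nM to 80000 nM.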

Compound 3, half-maximal inhibitory concentration: > 128000 nM
Compound 3: a limit, no number; the forecaster's own chance of this, stated with the estimate: 15%; middle value at least 5.8-fold (0.76 log units) from the limit.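

Having a halogen on this ring is not enough on its own: the change to 2,4-dichlorophenyl gives an at least 7.7-fold higher number from compound 1 to compound 3 (0.88 log units; beyond the scatter) in this assay. So far, 4-bromophenyl is the only group at this place with a readable number, and the step between compound 2 and compound 3 cannot be read. Compound 3 gives only a limit, as compound 2 does: the limit of > 128000 nM in this assay, at which 2 of the 3 values shown sit.

On these data alone, how far either compound lies past that limit stays open. So does whether 4-chlorophenyl, or an aminophenyl group, would give a readable number at this place.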